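Side chain exchange on compound 2

The source may report more compounds than this note shows. Statements on the series, on what has been measured and on what is new or still open speak of the compounds shown alone.

In a functional assay on HCT-116 cells (Homo sapiens) for inhibition (on this read-out higher numbers stand for an effect only at larger amounts of compound and lower numbers for an effect already at smaller amounts), compound 1 (`COc1cc(N2CCNCC2)ccc1Nc1nc(NC2CCCCC2)c2nc[nH]c2n1`) gives 160 nM and compound 2 (`COc1cc(N2CCC(CC(=O)N3CCN(C)CC3)CC2)ccc1Nc1nc(NC2CCCCC2)c2nc[nH]c2n1`) gives 65 nM as the lower of the two numbers, a gap beyond the scatter. Among the compounds with values here, these two compounds differ in more than one place, so no measured single-place step is available as a guide. The change from compound 2 to compound 3 (`COc1cc(N2CCC(C(=O)N3CC(O)C3)CC2)ccc1Nc1nc(NC2CCCCC2)c2nc[nH]c2n1`) is (3-hydroxyazetidin-1-yl)carbonyl in place of ((4-methylpiperazin-1-yl)carbonyl)methyl on a saturated ring carbon on a saturated ring carbon of a six-membered non-aromatic ring with 1 nitrogen. Within the data shown here, the shared core stays in place, and compound 1 at 160 nM marks the only other reading nearby. In this assay a small move towards a higher number is expected, the estimated step being a 1.7-fold higher number from compound 2 to compound 3 (0.23 log units; within the scatter) and so within the scatter. The estimate for compound 3 is 110 nM with an expected range from 35 nM to 350 nM as a loose guide.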

Compound 3, half-maximal effective concentration: 260 nM
Beside the measured number, compound 3's estimate is 2.4-fold (0.37 log units) below it, within the range that was stated.
By their numbers in this assay, from the lowest: compound 2; then compounds 1 and 3 (each within the scatter of the next).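

In this assay, within the data shown here, the exchange on a saturated ring carbon of the six-membered non-aromatic ring with 1 nitrogen gives a 4.0-fold higher number from compound 2 to compound 3 (0.60 log units; beyond the scatter) and is the only single-place step so far. With the shared core unchanged, this position is therefore not indifferent to its side chain. The step replaces the ring, the linkage to the carbonyl and the hydrogen-bond donor count all at once, and no measurement available here bears on the reason for the shift.

The compounds shown leave open which of these differences carries the step. A (4-methylpiperazin-1-yl)carbonyl group attached directly to the ring carbon, or an unsubstituted azetidin-1-ylcarbonyl group, would separate the linkage and the hydroxyl from the change of ring.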